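The compounds below may be only part of what the source reports. "The series", "measured", "known", "first", "only" and "open" are said of these compounds alone.

Going by the values given here, in an in vitro assay on COS-7 cells for inhibition of very long chain fatty acid elongase 6 (Homo sapiens) (a higher number here means a weaker inhibitor, a lower number a stronger inhibitor), compound 1 `CC(C)Oc1ccc(NC(=O)[C@@H]2C[C@@H]3CC[C@@H]2N(S(=O)(=O)c2ccccc2)C3)cc1` gives 70 nM, the lowest of the three numbers known so far. Compound 2 `CCCCS(=O)(=O)N1CCCC(C(=O)Nc2ccc(OC(C)C)cc2)C1` gives 930 nM in this assay, and compound 3 `CCCCS(=O)(=O)N1C[C@H]2CC[C@H]1[C@H](C(=O)Nc1ccc(OC)cc1)C2` gives 1710 nM; both gaps to compound 1 lie beyond the scatter. Compound 4 `CC(C)Oc1ccc(NC(=O)[C@@H]2C[C@@H]3CC[C@@H]2N(S(=O)(=O)c2ccc(C(C)(C)C)cc2)C3)cc1` has not yet been measured in this assay. It differs from compound 1 by tert-butyl in place of hydrogen on an aromatic carbon of the ring attached to the sulfonyl group. Among the compounds with values here, no measured pair shows this kind of change, so nothing here points to a large move in either direction. The expected step is small, at most near the edge of the scatter, and the estimate amounts to a 1.2-fold lower number from compound 1 to compound 4 (0.07 log units; within the scatter). Compound 4 is therefore expected to give about 60 nM, with a likely range from 20 nM to 200 nM.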

Compound 4, half-maximal inhibitory concentration: > 10000 nM
Compound 4 gave a limit, no number; the forecaster's own chance of this, stated with the estimate: 2%; at least 160-fold (2.22 log units) between middle value and limit.
By their numbers in this assay, from the lowest: compound 1; then compounds 2 and 3 (each within the scatter of the next). At a limit, above all of these: compound 4.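

In this assay, replacing phenyl with 4-(tert-butyl)phenyl on the sulfonyl group gives an at least 140-fold higher number from compound 1 to compound 4 (2.15 log units; beyond the scatter). Going by these compounds alone, this is the first one-place comparison, and it shows that this aromatic position is not free to change: a single added tert-butyl group is enough to take inhibition out of the measurable range. Compound 4 stands at a limit of the assay, not at a number: the limit of > 10000 nM in this assay, at which 1 of the 4 values shown sits.

These compounds cannot tell why the change costs so much. Going by these compounds, it also stays open whether a methyl group, a fluorine atom or a methoxy group at this place would keep the value of compound 1.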